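Sulfonamide Variation on the Piperidine Core Toward Compound 3

This account rests on a few compounds, and the source may have more. Where it says the series, first, only, none or still open, it means among the compounds named here.

Compound 1 `CCS(=O)(=O)N[C@H]1CCCN(C(C)=O)[C@H]1CO[C@H]1CC[C@@H](C(C)C)CC1`: 270 nM
Compound 2 `CCS(=O)(=O)N[C@H]1CCCN(C(C)=O)[C@H]1CO[C@H]1CC[C@H](C(C)C)CC1`: > 30000 nM

In a functional assay on CHO-K1 cells for agonist activity at Orexin receptor type 2 (Homo sapiens), read by FLIPR and calcium flux (on this read-out higher numbers stand for an effect only at larger amounts of compound and lower numbers for an effect already at smaller amounts), compound 1 gives 270 nM, the only number shown. For compound 2 the assay reports only a limit, > 30000 nM. The step of an at least 110-fold higher number from compound 1 to compound 2 (2.04 log units; beyond the scatter) is large because of the fact that compounds 1 and 2 differ only in the configuration as drawn. Compound 3 `CC(=O)N1CCC[C@H](N(C)S(C)(=O)=O)[C@@H]1CO[C@H]1CC[C@@H](C(C)C)CC1` instead carries methyl(methylsulfonyl)amino in place of (ethylsulfonyl)amino on a saturated ring carbon. Going by the values given here, no measured step bears on this change, since the single known step concerns configuration alone, so the expectation rests on compound 1 only. A modest weakening, a 3.0-fold higher number from compound 1 to compound 3 (0.47 log units; beyond the scatter), is expected, and compound 3 is estimated at 800 nM, within 150 nM to 8000 nM.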

Compound 3, half-maximal effective concentration: > 30000 nM
Compound 3 was reported as a limit; the forecaster's own chance of this, stated with the estimate: 15%; at least 37-fold (1.57 log units) between middle value and limit.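

In this assay, replacing (ethylsulfonyl)amino with methyl(methylsulfonyl)amino on this saturated ring carbon gives an at least 110-fold higher number from compound 1 to compound 3 (2.04 log units; beyond the scatter), so a change of group at this position, with configuration as in compound 1, can cost as much as the configuration change did. The entering group has 0 hydrogen-bond donors where the leaving group has 1. For compound 3, the value > 30000 nM is a limit and not a number.

The compounds shown leave open whether the methyl on the sulfonamide nitrogen or the shorter chain on sulfur accounts for the step. From the compounds shown here alone, how (methylsulfonyl)amino or methyl(ethylsulfonyl)amino would behave here also remains open.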